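A few compounds are considered here, and "the series" means these few. Any claim that something is new, unique, unknown or untested is made for them only; others in the source may bear on it.

Measured compounds:
Compound 1 `Nc1sc2c(c1-c1nc3cc(Cl)ccc3s1)CCC2` in an ADME assay on HepG2 cells (Homo sapiens) for cytotoxicity, read by MTT assay, with a stated time of 72 h (a higher number here means that more compound is tolerated, a lower number that less compound is tolerated), gives 67.8 ug/mL.
Compound 2 `Fc1ccc(/C=N/c2sc3c(c2-c2nc4ccccc4s2)CCC3)cc1` in this assay gives 302 ug/mL.
Compound 3 `Clc1ccc(/C=N/c2sc3c(c2-c2nc4ccccc4s2)CCC3)cc1` in this assay gives 431 ug/mL.

Compound 3 holds the highest of the three numbers. Its nearest neighbour is compound 2, and the step of a 1.4-fold higher number from compound 2 to compound 3 (0.15 log units; within the scatter) shows what chloro in place of fluoro did on the shared core. Among the compounds with values here, the gap from compound 1 to compound 3 is beyond the scatter, but no single-point step links these two.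

Compound 4 `Fc1ccccc1/C=N/c1sc2c(c1-c1nc3ccccc3s1)CCC2` is not yet measured. The change from compound 3 to compound 4 is 2-fluorophenyl in place of 4-chlorophenyl on a carbon with a double bond to nitrogen. Within the data shown here, the only measured step that bears on it is a 1.4-fold higher number from compound 2 to compound 3 (0.15 log units; within the scatter), which swapped the halogen on the phenyl group without leaving the scatter. Among the measured compounds shown here, no measured pair changes where the fluorine sits on the phenyl group, so that part of the change has no precedent here. Compound 2 carries fluorine on its phenyl group and gave 302 ug/mL. The step of a 1.3-fold lower number from compound 3 to compound 4 (0.12 log units; within the scatter) is therefore expected to stay within the scatter. For compound 4 in this assay the estimate is 330 ug/mL, with a range from 150 ug/mL to 700 ug/mL.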

Compound 4, half-maximal cytotoxic concentration: 394 ug/mL
Beside the measured number, compound 4's estimate is 1.2-fold (0.08 log units) below it; measured number inside the range.
By their numbers in this assay, from the lowest: compound 1; then compounds 2, 4 and 3 (each within the scatter of the next).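

Within the data shown here, compound 4 gives the first measured pair in which the fluorine changes place on the phenyl group: this assay shows a 1.3-fold higher number from compound 2 to compound 4 (0.12 log units; within the scatter), so the position of this halogen does not separate the two compounds here. The second step, with 2-fluorophenyl in place of 4-chlorophenyl at the same place, changes both the halogen and its place on the ring, and it reads a 1.1-fold lower number from compound 3 to compound 4 (0.04 log units; within the scatter), so compounds 2, 3 and 4 cannot be told apart in this assay and all three halogen-bearing phenyl groups sit together on the shared core. Nothing available accounts for this lack of separation, and the numbers describe it without explaining it.

The compounds shown carry only a single fluorine or chlorine on the phenyl group, so it remains open whether a methoxy group, a hydroxyl group, a dimethylamino group or a carboxylic acid at this place would stay within the same band. Among these compounds, compound 1 remains linked to the others by no single-place step, so its gap from them cannot be assigned to any one change.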